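The source may hold more compounds than are shown below. What is called first, only, known or untested is meant among the compounds shown, and "the series" means these compounds.

Measured compounds:
- compound 1, `COc1cc(Br)ccc1Nc1cc(NC(=O)Nc2c(Cl)cccc2Cl)ncn1`, 29.1%
- compound 2, `COc1ccc(C(F)(F)F)cc1Nc1cc(NC(=O)Nc2c(Cl)cccc2Cl)ncn1`, 33%
- compound 3, `COc1cc(NC(=O)Nc2cc(Nc3cc(C)cc(F)c3)ncn2)cc(OC)c1`, 24.5%

All three were read in a functional assay on NCI-H520 cells (Homo sapiens) for inhibition, read by MTT assay, with a stated time of 48 h, tested at 10 uM; on this read-out lower numbers stand for less inhibition and higher numbers for more inhibition at the one concentration tested (going by the name of the read-out). Compound 1 gives 29.1%, compound 2 gives 33% and compound 3 gives 24.5%. The gap from compound 1 to compound 2 lies within the scatter, as does the gap from compound 1 to compound 3, so the three numbers cannot be separated on the evidence in hand. Going by the values given here, no step between two measured compounds that differ in one place is available, so nothing is known yet about how any single change shifts this assay.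

Compound 4, `O=C(Nc1cc(Nc2ccc(F)c(Cl)c2)ncn1)Nc1c(Cl)cccc1Cl`, has not been measured. Against compound 1 it differs in one place: 3-chloro-4-fluorophenyl in place of 4-bromo-2-methoxyphenyl on a nitrogen on an aromatic ring. The shared core and the urea-bound dichlorophenyl part are unchanged. As the three measured compounds all sit within the scatter of each other despite differing aryl groups on the same nitrogen, the step from compound 1 to compound 4 is expected to be small, in no clear direction, and not beyond the scatter: a number 1.1 percentage points lower from compound 1 to compound 4 (within the scatter). Compound 4 is therefore estimated at 28% in this assay, with a range from 15% to 42%.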

Compound 4, a percentage reported as inhibition, at one concentration (the size of the read-out at that concentration, not a potency): 39.5%
Compound 4: middle estimate off by 11.5 percentage points, on the low side; the measured number falls inside the stated range.
By their numbers in this assay, from the lowest: compounds 3, 1, 2 and 4 (each within the scatter of the next, the first and the last beyond it).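

In this assay, the aryl group on a nitrogen on an aromatic ring now has its first readable step, with 3-chloro-4-fluorophenyl in place of 4-bromo-2-methoxyphenyl giving a number 10.4 percentage points higher from compound 1 to compound 4 (beyond the scatter) in this series. Going by these compounds alone, this single modest step shows that the read-out at this position can respond to the choice of aryl group, which the earlier compounds, with no one-place pair among them, could not show. Nothing at hand accounts for the step.

On these data alone, the change replaces the methoxy group and the bromine and brings in two different halogens all at once, so the contribution of each remains open. Also open, as far as these compounds go, is how this position would read with a carboxylic acid or a dimethylamino group on the aryl ring.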